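Phenacyl ether at the phenol position of the chromene series

This account rests on a few compounds, and the source may have more. Where it says the series, first, only, none or still open, it means among the compounds named here.

Measured compounds in a functional assay (trachea) with Rattus norvegicus as the target; a lower number here means a less potent compound, a higher number a more potent compound, by a factor of ten per unit of this negative logarithm:
- compound 1, `CC1(C)C=C(n2ccccc2=O)c2cc(C(=O)c3ccccc3)ccc2O1`: 6.21
- compound 2, `CC1(C)C=C(n2ccccc2=O)c2cc(C(=N)NO)ccc2O1`: 5.51
- compound 3, `CC1(C)C=C(n2ccccc2=O)c2cc(O)ccc2O1`: 5.31

Compound 3 stands lowest of the three numbers. Its nearest neighbour is compound 2, and that gap a number 0.20 log units lower from compound 2 to compound 3 (within the scatter) is within the scatter, so no order between compound 2 and compound 3 can be claimed. The gap to compound 1, a number 0.90 log units lower from compound 1 to compound 3 (beyond the scatter), is beyond the scatter.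

Compound 4, `CC1(C)C=C(n2ccccc2=O)c2cc(OCC(=O)c3ccccc3)ccc2O1`, differs from compound 3 by benzoylmethyl in place of hydrogen on an oxygen on an aromatic ring.

The step that bears most directly on this change is a number 0.90 log units lower from compound 1 to compound 3 (beyond the scatter), which shows that removing benzoyl from the aromatic carbon in favour of hydroxy costs a modest amount. The step of a number 0.70 log units lower from compound 1 to compound 2 (beyond the scatter) points the same way: replacing the benzoyl by a smaller, ring-free group also lowers the number. Compound 4 restores a benzoyl-containing group, now attached through the phenolic oxygen rather than directly to the ring, so a rise is expected, though whether the full size of the loss is recovered cannot be told from these three compounds.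

For compound 4 the expected step is a number 0.59 log units higher from compound 3 to compound 4 (beyond the scatter), and the estimated value is 5.9, with a range from 5.3 to 6.5.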

Compound 4, logarithm of the reciprocal of the active concentration, log(1/C): 4.69
Estimate against measurement, compound 4: 1.21 log units above; the measured number lies below the stated range.
By their numbers in this assay, from the lowest: compound 4; then compounds 3 and 2 (each within the scatter of the next); then compound 1.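

In this assay, placing benzoylmethyl on the oxygen of the aromatic ring gives a number 0.62 log units lower from compound 3 to compound 4 (beyond the scatter), so at this position the added group lowers the number rather than raising it. A benzoyl-containing group therefore does not give a high number wherever it is attached: compound 1, with benzoyl on the aromatic carbon, gives 6.21, while compound 4, with the group attached through oxygen, gives 4.69. Nothing available on this series accounts for the drop.

The compounds shown do not tell whether the drop comes with any substituent on this oxygen or with benzoylmethyl in particular. A methyl ether, a benzyl ether without the carbonyl, or a carboxylic acid on a short chain at the same oxygen would help separate these possibilities.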